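The compounds below may be only part of what the source reports. "The series", "measured", "known", "first", "only" and "open" are said of these compounds alone.

Measured so far:
compound 1, `Cn1nccc1-c1cc(C(F)(F)F)ccc1[C@H]1CCOc2cc(S(=O)(=O)Nc3ccncn3)ccc21`, 1180000 nM
compound 2, `Cc1ccc(-c2cc(C(F)(F)F)ccc2[C@H]2CCOc3cc(S(=O)(=O)Nc4ncc(F)cn4)ccc32)cn1`, 225000 nM

Both numbers come from a physicochemical assay for solubility; on this read-out higher numbers stand for higher solubility and lower numbers for lower solubility. Compound 2 has the lower of the two numbers, and the gap from it up to compound 1 is beyond the scatter. The two compounds differ from each other in more than one place, so no single step can be read from that gap. Compound 3, `Cc1ccc(-c2cc(C(F)(F)F)ccc2[C@H]2CCOc3cc(S(=O)(=O)Nc4ccncn4)ccc32)cn1`, is not yet measured. It differs from compound 2 in one place only: pyrimidin-4-yl in place of 5-fluoropyrimidin-2-yl on a sulfonamide nitrogen. The pyrimidin-4-yl that enters is the same group that compound 1 carries on its sulfonamide nitrogen, yet compound 1 also differs from compound 2 elsewhere, so the gap between them cannot be assigned to this change alone. For the measured compounds named here, with no measured step of this kind available, the expectation for compound 3 is an estimated step of a 2.0-fold higher number from compound 2 to compound 3 (0.30 log units; within the scatter), a modest rise that could also turn out to lie within the scatter. Compound 3 is therefore expected to give about 450000 nM in this assay, with the estimate spanning from 150000 nM to 1200000 nM.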

Compound 3, solubility: 181000 nM
Compound 3: middle estimate off by 2.5-fold (0.40 log units), on the high side, and the stated range covers the measured number.
By their numbers in this assay, from the lowest: compounds 3 and 2 (each within the scatter of the next); then compound 1.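

In this assay, pyrimidin-4-yl in place of 5-fluoropyrimidin-2-yl on a sulfonamide nitrogen gives a 1.2-fold lower number from compound 2 to compound 3 (0.09 log units; within the scatter), so on this core the two groups cannot be told apart at this position. The other single change now readable, 6-methylpyridin-3-yl in place of 1-methyl-1H-pyrazol-5-yl on an aromatic carbon, gives a 6.5-fold lower number from compound 1 to compound 3 (0.81 log units; beyond the scatter), and of the two changes only this one lies beyond the scatter. Nothing available on these compounds speaks to why either step has the size it does.

The compounds shown leave open whether the two sulfonamide groups would also stay within the scatter of each other on a core carrying 1-methyl-1H-pyrazol-5-yl, since each has been read here on a core carrying 6-methylpyridin-3-yl. They also leave open how a different kind of group would read in either place, such as a thiazole ring or an acetyl group on the sulfonamide nitrogen, or a plain phenyl ring or a morpholine on the aromatic carbon.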